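Arylsulfonyl tetrahydronaphthalene series: amidine replaced by methylurea

The compounds below may be only part of what the source reports. "The series", "measured", "known", "first", "only" and "open" are said of these compounds alone.

Measured so far:
- compound 1, `CC(=N)NCC1CCCc2cc(S(=O)(=O)c3ccccc3)ccc21`: 0.631 nM
- compound 2, `NC[C@@H]1CCCc2cc(S(=O)(=O)Cc3ccccc3)ccc21`: 158 nM
- compound 3, `O=C1CN=C(NC[C@@H]2CCCc3cc(S(=O)(=O)c4cccc(F)c4)ccc32)N1`: 0.1 nM

All three were run in an assay on isolated protein for displacement of a labelled ligand from 5-hydroxytryptamine receptor 6 (Homo sapiens); a lower number here means a stronger inhibitor, a higher number a weaker inhibitor. Compound 3 gives the lowest number of the three. The nearest is compound 1, whose number is higher by a margin beyond the scatter; the furthest is compound 2, whose number lies far higher, again beyond the scatter. No pair among these three differs in one place only, so the three values are read as they stand and not as single steps.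

Compound 4, `CNC(=O)NC[C@@H]1CCCc2cc(S(=O)(=O)c3cccc(F)c3)ccc21`, is the next member to be measured in this assay. It differs from compound 3 in one place: a group of 4 heavy atoms (2 carbon, 1 nitrogen, 1 oxygen; no ring) in place of a group of 6 heavy atoms (3 carbon, 2 nitrogen, 1 oxygen; one five-membered non-aromatic ring with 2 hetero atoms), on an amine nitrogen. The cyclic group on the amine nitrogen is the feature that sets compound 3 apart from compound 1 and compound 2, both of which carry a smaller open group at that nitrogen and both of which give higher numbers. On that basis the expectation is that the step of a 200-fold higher number from compound 3 to compound 4 (2.30 log units; beyond the scatter) lies well beyond the scatter, towards a higher number. Compound 4 is estimated at 20 nM, with the range 3 nM to 150 nM.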

Compound 4, inhibition constant: 0.398 nM
For compound 4 the middle estimate is 50-fold (1.70 log units) above the measured one; measured number below the stated range.
By their numbers in this assay, from the lowest: compound 3; then compounds 4 and 1 (each within the scatter of the next); then compound 2.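

In this assay the amine nitrogen of this series accepts the open methylcarbamoyl group in place of the five-membered ring, and the change gives a 4.0-fold higher number from compound 3 to compound 4 (0.60 log units; beyond the scatter) as a modest step. Among the compounds shown here, this is the first single-place reading at this position: it shows that the ring with 2 hetero atoms is not needed for a low number, since compound 4 still reads 0.398 nM without it, although the step does lie beyond the scatter. Nothing measured on these compounds accounts for the size of this step, or for which of the features that change with the ring matters to the reading.

The compounds shown leave open whether another open group on this nitrogen, such as acetyl or a longer chain ending in a carboxylic acid, would stay as close to compound 3 as methylcarbamoyl does. They also leave open whether a six-membered ring with 2 hetero atoms at the same nitrogen would read with compound 3 or further from it.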